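Isopropyl in Place of Carbamoyl on the Free Acid

This account rests on a few compounds, and the source may have more. Where it says the series, first, only, none or still open, it means among the compounds named here.

Measured so far:
compound 1, `O=C(CN(c1nc(Cl)nc2[nH]cnc12)C1CC1)N[C@@H](CO)C(=O)OCc1ccccc1`: 34.5%
compound 2, `NC(=O)C[C@H](NC(=O)CN(c1nc(Cl)nc2[nH]cnc12)C1CC1)C(=O)O`: 17%
compound 3, `NC(=O)C[C@H](NC(=O)CN(c1ncnc2c1ncn2C1CCCCO1)C1CC1)C(=O)OCc1ccccc1`: 29.2%

In a functional assay on the whole organism (Tail, strain ICR) with Mus musculus as the target, in the tail flick test, with a stated time of 120 min, at a dose of 25 umol/kg by the oral route (a lower number here means a weaker effect, a higher number a stronger effect of the compound at the dose given), compound 1 gives 34.5% and compound 3 gives 29.2%, while compound 2 gives 17%, the lowest of the three numbers. Compound 3 stands beyond the scatter above compound 2, and compound 1 stands further above still. Compound 4, `CC(C)C[C@H](NC(=O)CN(c1nc(Cl)nc2[nH]cnc12)C1CC1)C(=O)O`, differs from compound 2 by isopropyl in place of carbamoyl on a saturated chain carbon, two bonds along the chain from an amide-type nitrogen and a carbonyl carbon. For the measured compounds named here, no pair of measured compounds shows this change alone, so there is no measured step to lean on. Compound 4 is expected to give about 25%, somewhere between 10% and 45%. The step of a number 8 percentage points higher from compound 2 to compound 4 (within the scatter) is expected to be modest and upward, though it may well stay within the scatter.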

Compound 4, a percentage reported as activity, at one dose (the size of the read-out at that dose, not a potency): 18.7%
For compound 4 the middle estimate is 6.3 percentage points above the measured one, and the stated range covers the measured number.
By their numbers in this assay, from the lowest: compounds 2 and 4 (each within the scatter of the next); then compounds 3 and 1 (each within the scatter of the next).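

In this assay, isopropyl in place of carbamoyl on the free acid gives a number 1.7 percentage points higher from compound 2 to compound 4 (within the scatter). This first step at this saturated chain carbon shows that, at this dose, the read-out does not visibly depend on keeping the carbamoyl with its hydrogen-bond donor and acceptor. No accompanying measurement bears on this result.

The compounds shown leave open whether an amine or a longer chain on this carbon would also stay within the scatter of compound 2. They also leave open whether the same exchange would read alike on a benzyl ester.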